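Replacing 3-chlorophenyl with 2-methylphenyl

The source may report more compounds than this note shows. Statements on the series, on what has been measured and on what is new or still open speak of the compounds shown alone.

In a physicochemical assay for lipophilicity, read by HPLC, at pH 7.5 (on this read-out higher numbers stand for higher lipophilicity and lower numbers for lower lipophilicity), compound 3 `CC[C@@H](Nc1c(C#N)c(-c2ccc(-c3cccc(Cl)c3)cc2)nc2cnccc12)C(N)=O` gives 3.1, the highest of three numbers, against compound 1 `CC[C@@H](Nc1c(C#N)c(-c2ccc(-c3cccc(CO)c3)cc2)nc2cnccc12)C(N)=O` at 2 and compound 2 `CC[C@@H](Nc1c(C#N)c(-c2ccc(-c3cccnc3C)cc2)nc2cnccc12)C(N)=O` at 1.9. The step of a number 0.10 log units lower from compound 1 to compound 2 (within the scatter) stays within the scatter, whereas a number 1.10 log units higher from compound 1 to compound 3 (beyond the scatter) and a number 1.20 log units higher from compound 2 to compound 3 (beyond the scatter) are both large. Compound 4 `CC[C@@H](Nc1c(C#N)c(-c2ccc(-c3ccccc3C)cc2)nc2cnccc12)C(N)=O` carries 2-methylphenyl in place of 3-chlorophenyl on an aromatic carbon, para to a large group: 2-methylphenyl in place of 3-chlorophenyl on an aromatic carbon. Among the compounds with values here, no measured step makes this exact exchange. The closest guide is a number 1.20 log units higher from compound 2 to compound 3 (beyond the scatter), which also replaces a methyl-bearing group, but its 2-methylpyridin-3-yl ring is not carbon only. A small downward step in this assay is expected, within the scatter: a number 0.20 log units lower from compound 3 to compound 4 (within the scatter). Compound 4 is estimated at 2.9, with an expected range of 2.5 to 3.3.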

Compound 4, distribution coefficient: 3
Beside the measured number, compound 4's estimate is 0.10 log units below it, and the stated range covers the measured number.
By their numbers in this assay, from the lowest: compounds 2 and 1 (each within the scatter of the next); then compounds 4 and 3 (each within the scatter of the next).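

In this assay, 2-methylphenyl in place of 3-chlorophenyl gives a number 0.10 log units lower from compound 3 to compound 4 (within the scatter), so a ring bearing chlorine is not needed for a number at the top of this short series. Against the other two groups at this position, 2-methylphenyl gives a number 1.10 log units higher from compound 2 to compound 4 (beyond the scatter) and a number 1.00 log units higher from compound 1 to compound 4 (beyond the scatter), which places compound 3 and compound 4 together as the upper pair. Nothing available accounts for these steps. The compounds shown vary the substituent and its ring place together, so the contribution of each stays open. From the compounds shown here alone, how an amine or a carboxylic acid on this ring would read also stays open.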